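Carbamate Variations and Maximal Response at a Rat Receptor

A few compounds are considered here, and "the series" means these few. Any claim that something is new, unique, unknown or untested is made for them only; others in the source may bear on it.

Measured compounds:
- Compound 1, `Cc1nc(S(C)(=O)=O)ccc1Oc1ncnc(OC2CCN(C(=O)OC3CCC3)CC2)c1F`: 81%
- Compound 2, `Cc1nc(S(C)(=O)=O)ccc1Oc1ncnc(OC2CCN(C(=O)OC(C)(C)C(F)(F)F)CC2)c1F`: 79%
- Compound 3, `Cc1nc(S(C)(=O)=O)ccc1Oc1ncnc(OC2CCN(C(=O)O[C@@H](C)CF)CC2)c1F`: 84%

All three share one core and differ only in the group on an oxygen next to a carbonyl group. In a functional assay on isolated protein for inhibition of Glucose-dependent insulinotropic receptor (Rattus norvegicus), read by HTRF and cAMP accumulation (on this read-out higher numbers stand for larger maximal responses and lower numbers for smaller maximal responses), compound 2 gives 79%, which is the lowest of the three numbers, yet its gaps to the others are both within the scatter: a number 2 percentage points lower from compound 1 to compound 2 (within the scatter) and a number 5 percentage points higher from compound 2 to compound 3 (within the scatter). The third comparison, a number 3 percentage points higher from compound 1 to compound 3 (within the scatter), is likewise within the scatter. So far, then, exchanging this group has not moved the maximal response beyond the noise of the measurement.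

Compound 4, `CCC1(OC(=O)N2CCC(Oc3ncnc(Oc4ccc(S(C)(=O)=O)nc4C)c3F)CC2)CC1`, has not yet been measured. The change from compound 2 is 1-ethylcyclopropyl in place of 1-methyl-1-(trifluoromethyl)ethyl on an oxygen next to a carbonyl group. Among the compounds with values here, the step that bears most on it is the one from a ring-bearing group to the fluorinated group, a number 2 percentage points lower from compound 1 to compound 2 (within the scatter), together with a number 5 percentage points higher from compound 2 to compound 3 (within the scatter); both were small. Because a number 2 percentage points lower from compound 1 to compound 2 (within the scatter) and a number 5 percentage points higher from compound 2 to compound 3 (within the scatter) stayed within the scatter, no step beyond the scatter is expected here either: the expected change is a number 2 percentage points higher from compound 2 to compound 4 (within the scatter). The estimate for compound 4 in this assay is 81%, with an expected range from 72% to 90%.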

Compound 4, largest response reached (reported as efficacy), in percent of the reference or control that the assay uses: 83%
Compound 4: the middle estimate sits 2 percentage points below what was measured; measured number inside the range.
By their numbers in this assay, from the lowest: compounds 2, 1, 4 and 3 (each within the scatter of the next).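

In this assay, putting 1-ethylcyclopropyl, with its three-membered ring of carbon only, in place of 1-methyl-1-(trifluoromethyl)ethyl gives a number 4 percentage points higher from compound 2 to compound 4 (within the scatter), while the exchange for 1-(fluoromethyl)ethyl gives a number 1 percentage points lower from compound 3 to compound 4 (within the scatter) and the exchange for cyclobutyl gives a number 2 percentage points higher from compound 1 to compound 4 (within the scatter). Within the data shown here, all three new steps are small, so this oxygen next to a carbonyl group now carries four different groups, two with a carbon ring and two with fluorine, and no step among the four compounds leaves the scatter, with no compound going against this. The data give no measured property that could be tied to any of these groups, so the flat picture stays a plain observation with no explanation attached.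

All four groups are compact and uncharged, so a group carrying an amine or a carboxylic acid, or a longer chain, could behave quite differently at this position. These compounds also show only the largest response reached, leaving open whether the same exchanges change the concentration needed to reach it.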